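A few compounds are considered here, and "the series" means these few. Any claim that something is new, unique, unknown or untested is made for them only; others in the source may bear on it.

Compound 1 `COc1ncnc2c1c(-c1ccsc1)cn2[C@@H]1O[C@H](CO)[C@@H](O)[C@H]1O` is a sugar-bearing molecule whose core carries a methoxy group and a thiophen-3-yl group. In a functional assay on HL-60 cells (Homo sapiens) for antiproliferative activity, read by XTT assay, with a stated time of 72 h (on this read-out lower numbers stand for stronger inhibition and higher numbers for weaker inhibition), compound 1 gives 130 nM, the lowest of the two plain numbers shown. Two measured compounds differ from it in a single place. Compound 2 `COc1nc(N)nc2c1c(-c1ccsc1)cn2[C@@H]1O[C@H](CO)[C@@H](O)[C@H]1O` has an amino group in place of a hydrogen on the core; in this assay compound 2 gives > 20000 nM, which is a limit of the assay and not a number. That change brings an at least 150-fold higher number from compound 1 to compound 2 (2.18 log units; beyond the scatter). Compound 3 `CSc1ncnc2c1c(-c1ccsc1)cn2[C@@H]1O[C@H](CO)[C@@H](O)[C@H]1O` carries methylsulfanyl instead of methoxy; in this assay compound 3 gives 4590 nM, and the change brings a 35-fold higher number from compound 1 to compound 3 (1.55 log units; beyond the scatter). Compound 4 `COc1ncnc2c1c(-c1ccco1)cn2[C@@H]1O[C@H](CO)[C@@H](O)[C@H]1O`, not yet measured, differs from compound 1 at another place: furan-2-yl in place of thiophen-3-yl on an aromatic carbon. Neither measured step touches the thiophen-3-yl group, so none bears directly on this exchange; both only show that the core of compound 1 is very sensitive to changes elsewhere. With nothing shown about the aryl group itself, no step beyond the scatter is expected in this assay. Compound 4 is therefore estimated at 150 nM, with a range from 40 nM to 600 nM. This estimate means an expected step of a 1.2-fold higher number from compound 1 to compound 4 (0.06 log units; within the scatter).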

Compound 4, half-maximal inhibitory concentration: 100 nM
Compound 4: middle estimate off by 1.5-fold (0.18 log units), on the high side; measured number inside the range.
By their numbers in this assay, from the lowest: compounds 4 and 1 (each within the scatter of the next); then compound 3. At a limit, above all of these: compound 2.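

In this assay, putting furan-2-yl in place of thiophen-3-yl gives a 1.3-fold lower number from compound 1 to compound 4 (0.11 log units; within the scatter) and so leaves the two compounds indistinguishable on this read-out. Among these compounds, this is the first look at this position, on an aromatic carbon of the five-membered aromatic ring with 1 nitrogen, and it contrasts with the earlier changes elsewhere on the core, which both moved the number well beyond the scatter. The exchange is not a minimal one, since the ring hetero atom changes from sulfur to oxygen and the ring's point of attachment changes from 3-yl to 2-yl, yet this single pair shows that the position accepts both changes made together without a readable loss of activity.

Still open, going by these compounds, is whether this position would accept something other than a five-membered aromatic ring with 1 hetero atom, such as a phenyl ring, a short alkyl chain or an amine, and whether furan-2-yl would behave the same way alongside methylsulfanyl or the added amino group. Nothing shown here accounts for why the two rings give values so alike.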